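The compounds below may be only part of what the source reports. "The series", "measured", "known", "first", "only" and "open" are said of these compounds alone.

Compound 1 `Cc1cccc(Cn2cc(COc3ccc4c(=O)ccoc4c3)nn2)c1` stands at a limit in a functional assay on HeLa cells (Homo sapiens) for cytotoxicity, read by MTT assay, with a stated time of 48 h; on this read-out lower numbers stand for stronger inhibition and higher numbers for weaker inhibition: compound 1 gives > 100000 nM, a limit rather than a number. Compound 2 `Cc1ccc(Cn2cc(COc3ccc4c(=O)ccoc4c3)nn2)cc1` likewise gives > 100000 nM, again a limit. Compound 3 `O=c1ccoc2cc(OCc3cn(Cc4cccc(F)c4)nn3)ccc12` gives 7550 nM. Two of the three values sit at the limit of > 100000 nM in this assay, at which 2 of the 3 values shown sit, so the step that the two limits leave unreadable from compound 1 to compound 2 stays unreadable, while an at least 13-fold lower number from compound 2 to compound 3 (1.12 log units; beyond the scatter) is read as large. Compound 4 `O=c1ccoc2cc(OCc3cn(Cc4cccc([N+](=O)[O-])c4)nn3)ccc12` differs from compound 1 by nitro in place of methyl on an aromatic carbon. Among the compounds with values here, the only measured change on that aromatic carbon is an at least 13-fold lower number from compound 1 to compound 3 (1.12 log units; beyond the scatter), a large lowering; a lowering is therefore expected here too, though with wide uncertainty, and for compound 4 a step of an at least 5.0-fold lower number from compound 1 to compound 4 (0.69 log units; beyond the scatter) is estimated. The estimate for compound 4 is 20000 nM, between 5000 nM and 100000 nM.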

Compound 4, half-maximal inhibitory concentration: 17300 nM
For compound 4 the middle estimate is 1.2-fold (0.06 log units) above the measured one; low and high end bracket the measured number.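

In this assay, nitro joins fluoro as a second group on this aromatic carbon that gives a lower number than methyl, with an at least 5.7-fold lower number from compound 1 to compound 4 (0.76 log units; beyond the scatter) and, against the other methyl compound, an at least 5.7-fold lower number from compound 2 to compound 4 (0.76 log units; beyond the scatter). The two replacements are not equivalent, with a 2.3-fold higher number from compound 3 to compound 4 (0.36 log units; beyond the scatter), so the outcome depends on which group replaces methyl. The steps from the methyl compounds are bounded on one side only: the limit of > 100000 nM in this assay, at which 2 of the 4 values shown sit.

From the compounds shown here alone, whether an amine, a carboxylic acid or methoxy on this carbon would give a lower number remains open. Also open, going by these compounds, is how fluoro or nitro would behave on the ring carbon that carries methyl in compound 2.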